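The source may report more compounds than this note shows. Statements on the series, on what has been measured and on what is new or still open speak of the compounds shown alone.

Measured compounds:
Compound 1, `Cc1cccc(OC2CCN(c3ccc(-n4ccnc4)nn3)CC2)c1`: 251 nM
Compound 2, `CC(C)Cc1nnc(-c2ccc(N3CCC(Oc4ccccc4C(F)(F)F)CC3)nn2)o1`: 15 nM
Compound 3, `CC(C)(C)c1nnc(-c2ccc(N3CCC(Oc4ccccc4C(F)(F)F)CC3)nn2)s1`: 710 nM

In an assay on microsomes from liver for inhibition of acyl-CoA desaturase 1 (Rattus norvegicus) (on this read-out lower numbers stand for stronger inhibition and higher numbers for weaker inhibition), compound 1 stands second highest of the three numbers. Within the data shown here, compound 2 gives the lowest number, and compound 3 the highest; the one step measured between two compounds differing in a single place is a 47-fold higher number from compound 2 to compound 3 (1.68 log units; beyond the scatter), which concerns a heteroaryl exchange on the shared core and not the aryl ether end of the molecule.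

Compound 4, `CCc1cccc(OC2CCN(c3ccc(-n4ccnc4)nn3)CC2)c1`, is the next compound to be measured. It differs from compound 1 in one place: methyl in place of hydrogen on a saturated chain carbon bound to an aromatic carbon. Cut one bond further out, the change reads methyl to ethyl, or 3-methylphenyl to 3-ethylphenyl.

Among the measured compounds shown here, no measured step in this set bears on this kind of change. For the measured compounds named here, the only step available, from compound 2 to compound 3, alters a different part of the molecule and cannot be carried over to the aryl ether end. Without a comparable step, compound 4 is expected to give a number close to that of compound 1, with an estimated step of a 1.1-fold lower number from compound 1 to compound 4 (0.06 log units; within the scatter), which would fall within the scatter. The estimate for compound 4 in this assay is therefore 220 nM, with a range from 80 nM to 600 nM.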

Compound 4, half-maximal inhibitory concentration: 38 nM
Compound 4: middle estimate off by 5.8-fold (0.76 log units), on the high side; measured number outside the range, below it.
By their numbers in this assay, from the lowest: compound 2; then compound 4; then compound 1; then compound 3.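

In this assay the addition of one methyl, which turns 3-methylphenyl into 3-ethylphenyl, gives a 6.6-fold lower number from compound 1 to compound 4 (0.82 log units; beyond the scatter) and so shows that inhibition responds to a small change at the aryl ether end of the molecule. Among these compounds, the only earlier step, a 47-fold higher number from compound 2 to compound 3 (1.68 log units; beyond the scatter), concerned a heteroaryl exchange on the shared core and said nothing about this end, so compound 4 supplies the first reading of it: on a saturated chain carbon bound to an aromatic carbon, a single added carbon moves the number toward stronger inhibition by more than the usual scatter. Nothing measured here accounts for the size of this step, and the result stands as an observation without an explanation.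

A single step cannot show whether the trend continues with a longer chain such as propyl, or whether a branched group such as isopropyl or a ring such as cyclopropyl would behave as ethyl does in this place. It also leaves open whether the same methyl-to-ethyl change would have a similar effect on compounds carrying the 5-isobutyl-1,3,4-oxadiazol-2-yl group in place of the group on the core of compound 1.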